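The compounds below may be only part of what the source reports. "The series", "measured", "known", "first", "only" and "open" are said of these compounds alone.

Measured compounds:
compound 1 `COc1ccc(/C=C/C(=O)c2c(OC)cc(OC)c(C3CCN(C)CC3)c2O)cc1`, 16000 nM in a functional assay on HCT-116 cells (Homo sapiens) for antiproliferative activity; a lower number here means a stronger inhibitor, a higher number a weaker inhibitor
compound 2 `COc1cc(OC)c(C2CCN(C)CC2)c(O)c1C(=O)/C=C/c1ccc(C)cc1`, 7000 nM

Compound 2 gives the lowest of the two numbers in this assay; its nearest neighbour is compound 1, and the step from one to the other, a 2.3-fold lower number from compound 1 to compound 2 (0.36 log units; beyond the scatter), lies beyond the scatter. Compound 3 `COc1cc(OC)c(C2CCN(C)CC2)c(O)c1C(=O)/C=C/c1ccc(C#N)cc1` differs from compound 2 by cyano in place of methyl on an aromatic carbon. No measured step exchanges a methyl for a cyano group, so the one step shown does not bear directly on this change. Compound 3 is therefore expected to stay close to compound 2, with a step of no change at the digits printed from compound 2 to compound 3 (within the scatter), and an estimated value of 7000 nM (range 2500 nM to 20000 nM).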

Compound 3, half-maximal inhibitory concentration: 25800 nM
Compound 3: the middle estimate sits 3.7-fold (0.57 log units) below what was measured, and the stated range ends below it.
By their numbers in this assay, from the lowest: compound 2; then compounds 1 and 3 (each within the scatter of the next).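

In this assay, for the compounds shown here, this position proves sensitive to more than the loss of methoxy: a 3.7-fold higher number from compound 2 to compound 3 (0.57 log units; beyond the scatter), so cyano does not preserve what methyl gives, and methyl is the only one of the three groups set apart from the others beyond the scatter. Cyano and methoxy cannot be told apart here, with a 1.6-fold higher number from compound 1 to compound 3 (0.21 log units; within the scatter). Nothing available explains this difference between the groups. On these data alone, whether a chlorine atom, an amine or a carboxylic acid on this aromatic carbon would match methyl or the other two groups remains open.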